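A few compounds are considered here, and "the series" means these few. Any claim that something is new, unique, unknown or untested is made for them only; others in the source may bear on it.

Measured in an ADME assay on HFF cells (Homo sapiens) for cytotoxicity, with a stated time of 8 days; a lower number here means that less compound is tolerated, a higher number that more compound is tolerated:
Compound 1 `Nc1nc(N2CCCC2)c2ncn(/C=C3/CC3(CO)CO)c2n1`: > 300000 nM
Compound 2 `Nc1nc(SC2CCCC2)c2ncn(/C=C3/CC3(CO)CO)c2n1`: > 300000 nM

Compound 2 gives > 300000 nM, which is a limit of the assay and not a number. Compound 1 gives > 300000 nM, which is likewise a limit. Together, compound 1 and compound 2 stand at the limit of > 300000 nM in this assay, at which 2 of the 2 values shown sit.

Compound 3 `Nc1nc(SCc2ccccc2)c2ncn(/C=C3/CC3(CO)CO)c2n1` has benzyl in place of cyclopentyl on a sulfur whose other neighbour is an aromatic carbon: benzyl in place of cyclopentyl on a sulfur. Among the compounds with values here, the only measured step that bears on this change is a step that the two limits leave unreadable from compound 1 to compound 2. Its size cannot be read, so it gives no size to carry over, and it concerns a different replacement.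

Compound 2 sits at > 300000 nM, a limit, so any readable change in this assay is expected to be towards less compound tolerated. Within the data shown here, no step clearly beyond the scatter is expected, and the estimated change is an at least 1.2-fold lower number from compound 2 to compound 3 (0.07 log units; that floor lies within the scatter). Compound 3 is expected at 250000 nM, with an estimated range of 100000 nM to 300000 nM, and a further report at the limit would fit this expectation.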

Compound 3, half-maximal cytotoxic concentration: > 300000 nM
Compound 3: no number, only a limit; the forecaster's own chance of this, stated with the estimate: 65%; at least 1.2-fold (0.07 log units) between middle value and limit.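

In this assay compound 3 gives > 300000 nM as a limit of the assay, not a number. No step among compound 1, compound 2 and compound 3 can be read, and all three stand together: the limit of > 300000 nM in this assay, at which 3 of the 3 values shown sit.

From the compounds shown here alone, the concentration at which any of the three becomes cytotoxic stays open, as does any difference between them.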